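Amide-for-urea trim in the OVCAR-5 series

The source may hold more compounds than are shown below. What is called first, only, known or untested is meant among the compounds shown, and "the series" means these compounds.

Compound 3 `COc1cc(-c2nn(-c3cccc(NC(=O)Nc4ccc(Cl)c(C(F)(F)F)c4)c3)cc2-c2ccncc2)ccc1Cl` reports only a limit in a functional assay on OVCAR-5 cells (Homo sapiens) for inhibition, read by sulforhodamine B assay, with a stated time of 48 h (on this read-out lower numbers stand for higher toxicity in this test and higher numbers for lower toxicity in this test), giving > 32500 nM. Compound 1 `COc1cc(-c2nn(-c3cccc(NC(=O)Nc4ccc(Cl)c(Cl)c4)c3)cc2-c2ccncc2)ccc1Cl` likewise sits at a limit, with > 50000 nM. Compound 2 `COc1cc(-c2nn(-c3cccc(NC(=O)c4ccc(Cl)c(C(F)(F)F)c4)c3)cc2-c2ccncc2)ccc1Cl` also gives a limit, > 32500 nM. The steps a step that the two limits leave unreadable from compound 1 to compound 2, a step that the two limits leave unreadable from compound 1 to compound 3 and a step that the two limits leave unreadable from compound 2 to compound 3 therefore stay unreadable, as the limit of > 32500 nM in this assay, at which 2 of the 3 values shown sit, and the limit of > 50000 nM in this assay, at which 1 of the 3 values shown sits, show. Compound 4 `COc1cc(-c2nn(-c3cccc(NC(=O)c4ccccc4)c3)cc2-c2ccncc2)ccc1Cl` differs from compound 3 by phenyl in place of (4-chloro-3-(trifluoromethyl)phenyl)amino on a carbonyl carbon. Among the compounds with values here, the only step touching the same carbonyl position, from compound 2 to compound 3, gives no readable size, so no direction can be read for this assay and a further limit is the expected outcome. Compound 4 is estimated at 40000 nM, range 12000 nM to 120000 nM, an expected step that the limit leaves unreadable from compound 3 to compound 4.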

Compound 4, concentration lethal to 50% of the cells: > 100000 nM
Compound 4 was reported as a limit (the forecaster's own chance of this, stated with the estimate: 80%); at least 2.5-fold (0.39 log units) between middle value and limit.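

Compound 4 adds only another limit in this assay, so its steps from compound 1, compound 2 and compound 3 cannot be read: the limit of > 100000 nM in this assay, at which 1 of the 4 values shown sits. The compounds shown leave open how any carbonyl substituent here changes the lethal concentration.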